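Replacing acetyl on an amine nitrogen in compound 2

The source may hold more compounds than are shown below. What is called first, only, known or untested is meant among the compounds shown, and "the series" means these compounds.

Compound 1 `Cc1cn([C@@H]2O[C@H](CO[Si](C)(C)C(C)(C)C)[C@@]3(OS(=O)(=O)C=C3NCC(=O)O)[C@H]2O[Si](C)(C)C(C)(C)C)c(=O)n(C)c1=O`: 136000 nM
Compound 2 `CC(=O)NC1=CS(=O)(=O)O[C@@]12[C@@H](CO[Si](C)(C)C(C)(C)C)O[C@@H](n1cc(C)c(=O)n(C)c1=O)[C@@H]2O[Si](C)(C)C(C)(C)C`: > 200000 nM (a limit)

Both compounds were tested in a functional assay on HEL cells (Homo sapiens); a lower number here means that less compound is tolerated, a higher number that more compound is tolerated. Compound 2 stands at the limit of > 200000 nM in this assay, at which 1 of the 2 values shown sits. This is a limit of the assay and not a number, so compound 2 has no exact place on the scale.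

Compound 3 `COC(=O)CNC1=CS(=O)(=O)O[C@@]12[C@@H](CO[Si](C)(C)C(C)(C)C)O[C@@H](n1cc(C)c(=O)n(C)c1=O)[C@@H]2O[Si](C)(C)C(C)(C)C` shares the core of compound 2 and carries (methoxycarbonyl)methyl in place of acetyl on an amine nitrogen. For the measured compounds named here, only one measured step bears on this change, and it concerns the same nitrogen, with acetyl in place of carboxymethyl. That step is an at least 1.4-fold higher number from compound 1 to compound 2 (0.16 log units; that floor lies within the scatter). It is small on the evidence available, and it is known only as a floor. Compound 3 loses the acetyl that compound 2 carries, so a modest move towards lower numbers in this assay is expected, though one that may stay close to the scatter. The expected step is an at least 1.6-fold lower number from compound 2 to compound 3 (0.20 log units; that floor lies within the scatter). A reading at the limit of the assay would not be surprising. For compound 3 the estimated value is 125000 nM, with an expected range from 60000 nM to 200000 nM.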

Compound 3, half-maximal cytotoxic concentration: 160000 nM
Compound 3: middle estimate off by 1.3-fold (0.11 log units), on the low side, and the stated range covers the measured number.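

In this assay, methyl in place of hydrogen on an oxygen next to a carbonyl group gives a 1.2-fold higher number from compound 1 to compound 3 (0.07 log units; within the scatter), so carboxymethyl and (methoxycarbonyl)methyl on this amine nitrogen cannot be told apart here, and the exact values at this position now form a pair of their own. Going from acetyl to (methoxycarbonyl)methyl gives an at least 1.2-fold lower number from compound 2 to compound 3 (0.09 log units; that floor lies within the scatter), a floor that, like the earlier step from compound 1 to compound 2, stays within the scatter, so neither step yet shows that acetyl differs from the other two groups. The value of compound 2 is a limit of the assay and not a number: the limit of > 200000 nM in this assay, at which 1 of the 3 values shown sits.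

On these data alone, how far compound 2 truly lies from compound 1 and compound 3 remains open, and so does whether the acetyl group separates from the other two groups by more than the scatter. Also open, as far as these compounds go, is whether a longer chain ending in an amine, or a hydroxyethyl group, on the same nitrogen would move the number in this assay beyond the scatter.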